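Indene for benzocyclobutene on the shared amine-bearing chain

The compounds below may be only part of what the source reports. "The series", "measured", "known", "first", "only" and "open" are said of these compounds alone.

Within the data shown here, compound 2 `c1ccc2c(c1)CC2CCCN1CCN(c2cccc3c2OCCO3)CC1` is the lower of the two numbers measured so far in a functional assay on the whole organism for antagonist activity, with Rattus norvegicus as the target; a higher number here means that more compound is needed for the effect, a lower number that less compound is needed: in this assay compound 2 gives 0.18 mg/kg, while compound 1 `c1ccc2c(c1)CC(CCCN1CCN(c3cccc4c3OCCO4)CC1)C2` gives 0.47 mg/kg. Among the measured compounds shown here, the single measured step, a 2.6-fold lower number from compound 1 to compound 2 (0.42 log units; beyond the scatter), is modest but beyond the scatter, and it is the only comparison available.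

Compound 3 `C1=C(CCN2CCN(c3cccc4c3OCCO4)CC2)c2ccccc2C1` differs from compound 2 as follows: a group of 9 heavy atoms (9 carbon; one five-membered non-aromatic ring of carbon only, one six-membered aromatic ring of carbon only) in place of a group of 9 heavy atoms (9 carbon; one four-membered non-aromatic ring of carbon only, one six-membered aromatic ring of carbon only), on a saturated chain carbon, two bonds along the chain from an amine nitrogen in a ring. The five-membered non-aromatic ring that enters carries one double bond outside aromatic rings and sits two bonds along the chain from the amine nitrogen, whereas compound 1 carries its five-membered ring three bonds along the chain. The step from compound 1 to compound 2 therefore bears on this change only in part, since it exchanged the ring size alone. The expectation is a return toward the value of compound 1, a modest rise beyond the scatter, with the step expected from compound 2 to compound 3 being a 1.9-fold higher number from compound 2 to compound 3 (0.29 log units; within the scatter). Compound 3 is estimated at 0.35 mg/kg in this assay, with a range from 0.15 mg/kg to 0.9 mg/kg.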

Compound 3, dose for 50% inhibition: 0.45 mg/kg
Beside the measured number, compound 3's estimate is 1.3-fold (0.11 log units) below it; the range from low to high includes it.
By their numbers in this assay, from the lowest: compound 2; then compounds 3 and 1 (each within the scatter of the next).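

In this assay the move to compound 3 is a 2.5-fold higher number from compound 2 to compound 3 (0.40 log units; beyond the scatter) and gives up the low number of compound 2, so the four-membered non-aromatic ring is not matched here by a five-membered non-aromatic ring carrying one double bond outside aromatic rings, two bonds along the chain from an amine nitrogen in a ring. Compound 3 at 0.45 mg/kg and compound 1 at 0.47 mg/kg lie within the scatter of each other, so among these three compounds the two with a five-membered ring stand together, although the ring sits at a different place along the chain, and compound 2 alone stands apart. Nothing measured alongside these numbers accounts for the step and the reading stays one of numbers only.

From the compounds shown here alone, compound 3 carries the double bond and the place two bonds along the chain together, so the share of each in the step remains open. Also open, going by these compounds, is how a six-membered non-aromatic ring of carbon only, or a longer chain to the amine nitrogen, would stand against compound 2 in this assay on this shared core.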